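A few compounds are considered here, and "the series" means these few. Any claim that something is new, unique, unknown or untested is made for them only; others in the source may bear on it.

Series notes. Compound 1 `Oc1cccc(-c2cc(-c3cccc(C(F)(F)F)c3)cc(-c3cccc(O)c3)n2)c1` and compound 2 `Oc1cccc(-c2cc(-c3ccc(C(F)(F)F)cc3)cc(-c3cccc(O)c3)n2)c1` share a core carrying two 3-hydroxyphenyl groups. In a functional assay on T47D cells (Homo sapiens) for inhibition (on this read-out lower numbers stand for stronger inhibition and higher numbers for weaker inhibition), compound 1 gives 4970 nM. In this assay compound 2 gives 2330 nM. The change between them, (4-(trifluoromethyl)phenyl in place of 3-(trifluoromethyl)phenyl on an aromatic carbon), brings a 2.1-fold lower number from compound 1 to compound 2 (0.33 log units; beyond the scatter). Compound 3 `Oc1ccc(-c2cc(-c3cccc(C(F)(F)F)c3)cc(-c3ccc(O)cc3)n2)cc1` carries two 4-hydroxyphenyl groups instead; the difference between the two cores is not broken down here. For compound 3, this assay reports only a limit, > 50000 nM. This is the limit of > 50000 nM in this assay, at which 1 of the 3 values shown sits. Compound 4 `Oc1ccc(-c2cc(-c3ccc(C(F)(F)F)cc3)cc(-c3ccc(O)cc3)n2)cc1` has not been measured. From compound 3 to compound 4 the change is 4-(trifluoromethyl)phenyl in place of 3-(trifluoromethyl)phenyl on an aromatic carbon, the same kind of change as from compound 1 to compound 2, the place differing in that it sits meta to two 4-hydroxyphenyl groups rather than meta to two 3-hydroxyphenyl groups. The expected step is a step that the limit leaves unreadable from compound 3 to compound 4, resting on a 2.1-fold lower number from compound 1 to compound 2 (0.33 log units; beyond the scatter) for the same kind of change. Compound 3 stands at a limit, and the step from it is loosely fixed. Compound 4 is expected at 60000 nM, in a range from 20000 nM to 200000 nM, and a limit rather than a number remains likely.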

Compound 4, half-maximal inhibitory concentration: > 50000 nM
Compound 4 ended at the assay's limit (the forecaster's own chance of this, stated with the estimate: 65%); the middle value does not contradict the limit.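

Compound 3 and compound 4 both stand at a limit in this assay, so no step between them can be read: the limit of > 50000 nM in this assay, at which 2 of the 4 values shown sit.

The compounds shown leave open whether 4-(trifluoromethyl)phenyl in place of 3-(trifluoromethyl)phenyl changes the read-out at all on the core carrying two 4-hydroxyphenyl groups.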